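Oral exposure notes on the step to compound 4

The compounds below may be only part of what the source reports. "The series", "measured", "known", "first", "only" and "open" are said of these compounds alone.

Compound 1 `CC(=O)c1cccc([C@@H](O)[C@H](O)[C@H](O)CO)n1` gives 10500 ng.h/mL
Compound 2 `CC(=O)c1nc([C@@H](O)[C@H](O)[C@H](O)CO)c(C)[nH]1` gives 2640 ng.h/mL
Compound 3 `CC(O)c1nc([C@@H](O)[C@H](O)[C@H](O)CO)c[nH]1` gives 10300 ng.h/mL

All three values come from an ADME assay on the whole organism (plasma, strain 129/SvEvBrd x C57BL/6) for pharmacokinetics, with Mus musculus as the target, at a dose of 10 mg/kg by the oral route (on this read-out higher numbers stand for higher exposure at the dose given and lower numbers for lower exposure), and compound 3 stands level with compound 1 within the scatter. Compound 3 lies beyond the scatter above compound 2.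

The next structure is compound 4 `Cc1nc(-c2nc([C@@H](O)[C@H](O)[C@H](O)CO)c[nH]2)cs1` which carries 2-methyl-1,3-thiazol-4-yl in place of 1-hydroxyethyl on an aromatic carbon and is otherwise the same as compound 3.

For the measured compounds named here, no measured pair differs in one place, so no measured step speaks directly to this change. Going by the values given here, the only guide is the spread of the measured values, and compound 2 at 2640 ng.h/mL marks its low end. A moderate fall is expected in this assay and the estimated step of a 2.6-fold lower number from compound 3 to compound 4 (0.41 log units; beyond the scatter) carries wide uncertainty. For compound 4 the estimated value is 4000 ng.h/mL with an expected range from 900 ng.h/mL to 14000 ng.h/mL around it.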

Compound 4, area under the concentration-time curve: 1970 ng.h/mL
The estimate for compound 4 lay 2.0-fold (0.31 log units) above the measured number; the measured number falls inside the stated range.
By their numbers in this assay, from the lowest: compounds 4 and 2 (each within the scatter of the next); then compounds 3 and 1 (each within the scatter of the next).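

In this assay, placing 2-methyl-1,3-thiazol-4-yl instead of 1-hydroxyethyl on the aromatic carbon between two ring nitrogen atoms gives a 5.2-fold lower number from compound 3 to compound 4 (0.72 log units; beyond the scatter). For the compounds shown here, this is the only measured one-place step, and it shows that oral exposure at this position depends on the group it carries, at least for this exchange. Nothing measured here gives a reason for the fall.

One step cannot tell whether the fall goes with the aromatic ring that enters or with the hydroxyl that leaves. On these data alone, it also remains open whether an ethyl chain, an amine or a carboxylic acid on the same aromatic carbon would keep exposure near the level of compound 3 at 10300 ng.h/mL.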